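This account rests on a few compounds, and the source may have more. Where it says the series, first, only, none or still open, it means among the compounds named here.

Of the compounds shown here, three sharing one core have been measured in a functional assay on A549 cells (Homo sapiens) for antiproliferative activity, read by MTT assay, with a stated time of 72 h; a higher number here means a weaker inhibitor, a lower number a stronger inhibitor. Compound 1 `CC(C)OC1=C(C(=O)c2ccccc2)C(c2ccc(Br)cc2)N(CCCn2ccnc2)C1=O` gives 8720 nM. Compound 2 `CCCCCOC1=C(C(=O)c2ccccc2)C(c2ccc(Br)cc2)N(CCCn2ccnc2)C1=O` gives 7290 nM, and compound 3 `Cc1ccc(NC2=C(C(=O)c3ccccc3)C(c3ccc(Br)cc3)N(CCCn3ccnc3)C2=O)cc1` gives 29400 nM. Compound 2 carries the lowest of the three numbers, but its separation from compound 1, a 1.2-fold lower number from compound 1 to compound 2 (0.08 log units; within the scatter), lies within the scatter, so the two cannot be told apart; only compound 3 is clearly set apart, by a 4.0-fold higher number from compound 2 to compound 3 (0.61 log units; beyond the scatter) and by a 3.4-fold higher number from compound 1 to compound 3 (0.53 log units; beyond the scatter).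

Compound 4 `O=C(C1=C(Nc2ccc(OC(F)(F)F)cc2)C(=O)N(CCCn2ccnc2)C1c1ccc(Br)cc1)c1ccccc1` is yet to be measured in this assay. Relative to compound 2 it shows ((4-(trifluoromethoxy)phenyl)amino in place of pentyloxy on a double-bonded ring carbon). The measured steps that bear on this change are the two in which (4-methylphenyl)amino replaced an alkoxy group on a double-bonded ring carbon: a 4.0-fold higher number from compound 2 to compound 3 (0.61 log units; beyond the scatter) and a 3.4-fold higher number from compound 1 to compound 3 (0.53 log units; beyond the scatter), both modest rises beyond the scatter. Within the data shown here, compound 4 differs from compound 3 only in carrying (4-(trifluoromethoxy)phenyl)amino where compound 3 carries (4-methylphenyl)amino, and no measured step covers that exchange, so the expectation rests on the alkoxy-to-arylamino steps alone. Compound 4 is therefore expected to give a higher number in this assay, a step of about a 3.6-fold higher number from compound 2 to compound 4 (0.55 log units; beyond the scatter). For compound 4 the estimated value is 26000 nM, expected to fall between 10000 nM and 65000 nM.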

Compound 4, half-maximal inhibitory concentration: 20800 nM
The estimate for compound 4 lay 1.3-fold (0.10 log units) above the measured number, and the stated range covers the measured number.
By their numbers in this assay, from the lowest: compounds 2 and 1 (each within the scatter of the next); then compounds 4 and 3 (each within the scatter of the next).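

In this assay, the rise seen on replacing an alkoxy group with an arylamino group on this double-bonded ring carbon recurs with a second arylamino group, as (4-(trifluoromethoxy)phenyl)amino gives a 2.9-fold higher number from compound 2 to compound 4 (0.46 log units; beyond the scatter) and also a 2.4-fold higher number from compound 1 to compound 4 (0.38 log units; beyond the scatter), both beyond the scatter. The substituent on the aromatic ring of the arylamino group makes no readable difference here, since trifluoromethoxy in place of methyl gives only a 1.4-fold lower number from compound 3 to compound 4 (0.15 log units; within the scatter), which lies within the scatter, so among these four compounds the higher numbers go with the two arylamino groups, whichever of these substituents they carry. Nothing available explains why the alkoxy and arylamino groups differ at this position.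

The compounds shown leave open whether a pentylamino chain on this carbon would fall with the alkoxy compounds or with the arylamino compounds, and so whether the step follows the nitrogen link or the aromatic ring it carries. They also leave open whether a carboxylic acid or a dimethylamino group on that aromatic ring would shift the number beyond the scatter, as methyl and trifluoromethoxy do not.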